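The source may report more compounds than this note shows. Statements on the series, on what has been measured and on what is new or still open speak of the compounds shown alone.

Working notes on the series. The shared core is kept throughout; only the aryl group on the amine nitrogen in the ring is varied. Compound 3 `O=C1c2ccccc2S(=O)(=O)N1CCCCCCN1CCN(c2ccc(Cl)c(Cl)c2)CC1` bears 3,4-dichlorophenyl and in an ADME assay on HEK293 cells for displacement of a labelled ligand from 5-hydroxytryptamine receptor 7 (Homo sapiens), read by radioligand binding, with a stated time of 1 h (on this read-out lower numbers stand for stronger inhibition and higher numbers for weaker inhibition), compound 3 gives 258 nM. Compound 1 `O=C1c2ccccc2S(=O)(=O)N1CCCCCCN1CCN(c2ccccc2F)CC1`, with 2-fluorophenyl, gives 322 nM in this assay. Compound 2 `O=C1c2ccccc2S(=O)(=O)N1CCCCCCN1CCN(c2cccc(Cl)c2Cl)CC1`, with 2,3-dichlorophenyl, gives 119 nM in this assay. Compound 3 stands second highest of the three numbers: a 1.2-fold lower number from compound 1 to compound 3 (0.10 log units; within the scatter) lies within the scatter, whereas a 2.2-fold higher number from compound 2 to compound 3 (0.34 log units; beyond the scatter) and a 2.7-fold lower number from compound 1 to compound 2 (0.43 log units; beyond the scatter) are modest steps beyond it.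

Compound 4 `O=C1c2ccccc2S(=O)(=O)N1CCCCCCN1CCN(c2ccccc2C(F)(F)F)CC1` differs from compound 3 by 2-(trifluoromethyl)phenyl in place of 3,4-dichlorophenyl on an amine nitrogen in a ring. Among the measured compounds shown here, no measured step introduces 2-(trifluoromethyl)phenyl, so the bearing is indirect: the whole aryl variation so far spans only a 2.7-fold lower number from compound 1 to compound 2 (0.43 log units; beyond the scatter), and the two 2-substituted aryl groups bracket compound 3 on either side. The expected step is therefore a 1.3-fold lower number from compound 3 to compound 4 (0.11 log units; within the scatter), not beyond the scatter. Compound 4 is estimated at 200 nM in this assay, with a range of 80 nM to 550 nM.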

Compound 4, inhibition constant: 195 nM
The estimate for compound 4 lay 1.0-fold (0.01 log units) above the measured number, and the stated range covers the measured number.
By their numbers in this assay, from the lowest: compounds 2, 4, 3 and 1 (each within the scatter of the next, the first and the last beyond it).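

In this assay, 2-(trifluoromethyl)phenyl on the amine nitrogen in the ring cannot be told apart from any of the three earlier aryl groups: a 1.3-fold lower number from compound 3 to compound 4 (0.12 log units; within the scatter) is joined by a 1.6-fold higher number from compound 2 to compound 4 (0.21 log units; within the scatter) and by a 1.7-fold lower number from compound 1 to compound 4 (0.22 log units; within the scatter) as steps that do not leave the scatter. Among the compounds shown here, compound 4 therefore adds a third substituent pattern to the series, and trifluoromethyl in place of fluoro on an aromatic carbon gives no readable change, while the gap between the two dichlorophenyl compounds remains the only aryl change read beyond the scatter apart from the 2-fluorophenyl to 2,3-dichlorophenyl step. Nothing at hand offers an explanation for these numbers.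

From the compounds shown here alone, whether a methoxy or nitrile group on the phenyl, or a pyridine ring in its place, would move the number further stays open. So does the effect of a shorter chain between the shared core and the amine nitrogen.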